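Compound 4: 1-benzofuran-2-yl in place of thiophen-2-yl

This account rests on a few compounds, and the source may have more. Where it says the series, first, only, none or still open, it means among the compounds named here.

Measured in an ADME assay on MRC5 cells (Homo sapiens), read by MTT assay, with a stated time of 72 h; on this read-out higher numbers stand for weaker inhibition and lower numbers for stronger inhibition:
- Compound 1 `Nc1nc(N)c2c(-c3cccs3)cn([C@@H]3O[C@H](CO)[C@@H](O)[C@H]3O)c2n1`: > 100000 nM (a limit)
- Compound 2 `Nc1nc(N)c2c(-c3cc4ccccc4o3)cn([C@@H]3O[C@H](CO)[C@@H](O)[C@H]3O)c2n1`: 78500 nM
- Compound 3 `Cc1nc(N)c2c(-c3cccs3)cn([C@@H]3O[C@H](CO)[C@@H](O)[C@H]3O)c2n1`: > 100000 nM (a limit)

Compound 4 `Cc1nc(N)c2c(-c3cc4ccccc4o3)cn([C@@H]3O[C@H](CO)[C@@H](O)[C@H]3O)c2n1` has not yet been measured.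

Compound 3 stands at > 100000 nM in this assay, which is a limit and not a number. That is the limit of > 100000 nM in this assay, at which 2 of the 3 values shown sit. Compound 4 differs from it in one place, with 1-benzofuran-2-yl in place of thiophen-2-yl on an aromatic carbon. The same exchange has one measured step, an at least 1.2-fold lower number from compound 1 to compound 2 (0.10 log units; that floor lies within the scatter). The other measured step, a step that the two limits leave unreadable from compound 1 to compound 3, gives no size to carry over. A small move to a lower number is therefore expected, and another limit remains possible. The expected change is an at least 1.2-fold lower number from compound 3 to compound 4 (0.09 log units; that floor lies within the scatter). For compound 4 the estimate is 80000 nM, with an expected range of 35000 nM to 100000 nM.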

Compound 4, half-maximal inhibitory concentration: 91800 nM
Estimate against measurement, compound 4: 1.1-fold (0.06 log units) below, within the range that was stated.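

In this assay the exchange of methyl for amino on an aromatic carbon now has a readable size, with a 1.2-fold higher number from compound 2 to compound 4 (0.07 log units; within the scatter) as the step on the 1-benzofuran-2-yl compounds. The exchange of thiophen-2-yl for 1-benzofuran-2-yl, now seen on a second core, gives an at least 1.0-fold lower number from compound 3 to compound 4 (0.03 log units; that floor lies within the scatter) as a floor and no full size: the same change on two cores in this assay, an at least 1.2-fold lower number (0.10 log units; that floor lies within the scatter) from compound 1 to compound 2 and an at least 1.0-fold lower number (0.03 log units; that floor lies within the scatter) from compound 3 to compound 4; the limit leaves it open whether they differ.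

Much of the series also remains unresolved at the top of the scale: the limit of > 100000 nM in this assay, at which 2 of the 4 values shown sit. Open, on these data alone, is whether a carboxylic acid on the 1-benzofuran-2-yl group, or a longer chain in place of methyl, would give a step beyond the scatter in this assay at all.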